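A few compounds are considered here, and "the series" means these few. Any claim that something is new, unique, unknown or untested is made for them only; others in the source may bear on it.

Compound 1, with the structure `Cc1ccccc1C1(CNC(=O)Nc2c(C(C)C)cccc2C(C)C)CCCC1`, is the starting point here. In an assay on microsomes for inhibition of acyl-CoA:cholesterol acyltransferase (Oryctolagus cuniculus) (a lower number here means a stronger inhibitor, a higher number a weaker inhibitor), compound 1 gives 17 nM. Among the three measured compounds this is the lowest number, but the others sit close to it. Compound 2 `CC(C)c1cccc(C(C)C)c1NC(=O)NCC1(c2cccc(N)c2)CCCC1` gives 21 nM, and the step of a 1.2-fold higher number from compound 1 to compound 2 (0.09 log units; within the scatter) is within the scatter. Compound 3 `COC(=O)c1cccc(C2(CNC(=O)Nc3c(C(C)C)cccc3C(C)C)CCCC2)c1` gives 34 nM, and the step of a 2.0-fold higher number from compound 1 to compound 3 (0.30 log units; within the scatter) also stays within the scatter, as does the step of a 1.6-fold higher number from compound 2 to compound 3 (0.21 log units; within the scatter).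

The next compound to consider is compound 4, with the structure `COC(=O)c1ccc(C2(CNC(=O)Nc3c(C(C)C)cccc3C(C)C)CCCC2)cc1`. Relative to compound 1 its change is 4-(methoxycarbonyl)phenyl in place of 2-methylphenyl on a saturated ring carbon. The most closely related measured step is a 2.0-fold higher number from compound 1 to compound 3 (0.30 log units; within the scatter), where the same methoxycarbonyl-bearing phenyl ring, differing only in the written position of the ester, replaced the same 2-methylphenyl group on the same saturated ring carbon; that step was small. The steps of a 1.2-fold higher number from compound 1 to compound 2 (0.09 log units; within the scatter) and a 1.6-fold higher number from compound 2 to compound 3 (0.21 log units; within the scatter) show that swapping groups on this phenyl ring has so far moved the number little.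

Compound 4 is therefore expected to give about 30 nM, with a likely range from 12 nM to 90 nM. This estimate for compound 4 means a step of a 1.8-fold higher number from compound 1 to compound 4 (0.25 log units; within the scatter), not clearly beyond the scatter.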

Compound 4, half-maximal inhibitory concentration: 360 nM
Estimate against measurement, compound 4: 12-fold (1.08 log units) below; measured number outside the range, above it.
By their numbers in this assay, from the lowest: compounds 1, 2 and 3 (each within the scatter of the next); then compound 4.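

Moving the methoxycarbonyl group on the phenyl ring, so that 4-(methoxycarbonyl)phenyl stands on the saturated ring carbon in place of 3-(methoxycarbonyl)phenyl, gives an 11-fold higher number from compound 3 to compound 4 (1.02 log units; beyond the scatter) in this assay, so the same group on the same ring can behave very differently depending on where the ring carries it. The other two comparisons point the same way, with a 21-fold higher number from compound 1 to compound 4 (1.33 log units; beyond the scatter) and a 17-fold higher number from compound 2 to compound 4 (1.23 log units; beyond the scatter), which sets compound 4 apart from three compounds that lie within the scatter of one another and shows that this ring does not accept every change as readily as those three suggested. Nothing shown here gives a measured reason for this large step.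

The compounds shown leave open whether the higher number belongs to the methoxycarbonyl group itself or would come with any group placed as it is in compound 4. A 4-aminophenyl or 4-methylphenyl ring, or a phenyl ring with a carboxylic acid in that same place, would help tell these two readings apart.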